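From 4-methylbenzyl to 3-azido-4-methoxybenzyl in compound 3

A few compounds are considered here, and "the series" means these few. Any claim that something is new, unique, unknown or untested is made for them only; others in the source may bear on it.

In a functional assay on KYSE-450 cells (Homo sapiens) for inhibition, read by CCK-8 assay, with a stated time of 48 h (on this read-out lower numbers stand for stronger inhibition and higher numbers for weaker inhibition), compound 1 `COc1ccc(CN(C(=O)CSC(=S)N2CCCc3cc(OC)ccc32)c2cc(OC)c(OC)c(OC)c2)cc1` gives a measured number, 5530 nM. Compound 2 `COc1cc(N(Cc2ccc(C)cc2)C(=O)CSC(=S)N2CCN(C(=O)OC(C)(C)C)CC2)cc(OC)c1OC` gives > 20000 nM, which is a limit of the assay and not a number. Of the two values available, this is the limit of > 20000 nM in this assay, at which 1 of the 2 values shown sits.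

Compound 3 `COc1ccc(CN(C(=O)CSC(=S)N2CCN(C(=O)OC(C)(C)C)CC2)c2cc(OC)c(OC)c(OC)c2)cc1N=[N+]=[N-]` carries 3-azido-4-methoxyphenyl in place of 4-methylphenyl on a saturated chain carbon bound to an amide-type nitrogen. For the measured compounds named here, no measured step isolates this change, so any expectation rests on thin ground. Going by the values given here, compound 1 at 5530 nM shows only that a number can be read within the range of this assay. A modest move toward stronger inhibition is expected, and a second result at the limit would remain plausible. The expected size is an at least 1.4-fold lower number from compound 2 to compound 3 (0.15 log units; that floor lies within the scatter). The estimate for compound 3 is 14000 nM, with an expected range of 6000 nM to 30000 nM.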

Compound 3, half-maximal inhibitory concentration: 840 nM
Compound 3: middle estimate off by 17-fold (1.22 log units), on the high side, and the stated range ends above it.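

Exchanging 4-methylbenzyl for 3-azido-4-methoxybenzyl, with the rest of the core unchanged, gives an at least 23-fold lower number from compound 2 to compound 3 (1.37 log units; beyond the scatter) in this assay. For the compounds shown here, this is the first single-place step, and it shows that the aryl group on a saturated chain carbon bound to an amide-type nitrogen can, by itself, carry a compound from the limit into the measurable range. Compound 2 stands at a limit and not at a number, so the step has a floor but no fixed size: the limit of > 20000 nM in this assay, at which 1 of the 3 values shown sits.

The compounds shown do not separate the azido group from the methoxy group, so the share of each in the step remains open. As far as these compounds go, whether a 3-amino-4-methoxybenzyl group at this place would keep the gain is also open.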